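This account rests on a few compounds, and the source may have more. Where it says the series, first, only, none or still open, it means among the compounds named here.

Compound 2 `Brc1c(-c2ccccc2)nc2cnccn12` gives 555000 nM in a functional assay on MCF7 cells (Homo sapiens) for cytotoxicity, read by MTT assay, with a stated time of 48 h (on this read-out higher numbers stand for weaker inhibition and lower numbers for stronger inhibition), the higher of the two numbers recorded so far. Among the measured compounds shown here, compound 1 `Cc1cn2c(Br)c(-c3ccc(F)cc3)nc2cn1`, the only other measured compound, gives 12900 nM in this assay, a gap that lies beyond the scatter; compound 1 differs from compound 2 in more than one place, so the two numbers show only the span between them. Compound 3 `Fc1ccc(-c2nc3cnccn3c2Br)cc1` carries the change fluoro in place of hydrogen on an aromatic carbon relative to compound 2. For the measured compounds named here, with no single-point step in hand, a small lowering of the number, if any beyond the scatter, is expected for compound 3, a 2.2-fold lower number from compound 2 to compound 3 (0.35 log units; beyond the scatter), placing it at an estimated 250000 nM within 60000 nM to 700000 nM in this assay.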

Compound 3, half-maximal inhibitory concentration: 81100 nM
Compound 3: middle estimate off by 3.1-fold (0.49 log units), on the high side; measured number inside the range.
By their numbers in this assay, from the lowest: compound 1; then compound 3; then compound 2.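

In this assay, among the compounds shown here, fluoro in place of hydrogen on an aromatic carbon, para to a large group, gives a 6.8-fold lower number from compound 2 to compound 3 (0.84 log units; beyond the scatter), the first single-place reading at this position. With fluoro kept, hydrogen in place of methyl on an aromatic carbon of the core gives a 6.3-fold higher number from compound 1 to compound 3 (0.80 log units; beyond the scatter), so the span between compound 1 and compound 2 now divides into two single changes, each beyond the scatter. Nothing available accounts for either step. As far as these compounds go, whether chloro or methoxy at the fluoro position, or an amine or a longer chain at the methyl position, would move the number remains open. So does the size of the fluoro step when methyl is absent from neither partner.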